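Lengthening an Amine Chain on Two Related Cores

The source may hold more compounds than are shown below. What is called first, only, known or untested is meant among the compounds shown, and "the series" means these compounds.

Compound 1, `CCCCNC1=CC(=O)C=C(C(C)(C)C)C1=O`, carries a butyl chain on its amine nitrogen. In a functional assay on NCI-H460 cells (Homo sapiens) for cytotoxicity, read by MTT assay, with a stated time of 72 h (a lower number here means a stronger inhibitor, a higher number a weaker inhibitor), compound 1 gives 14000 nM. Compound 2, `CCCCCCCCNC1=CC(=O)C=C(C(C)(C)C)C1=O`, differs from it only by butyl in place of hydrogen on a saturated chain carbon, four bonds along the chain from an amine nitrogen, so that the chain on the amine grows from butyl to octyl. In this assay compound 2 gives 20000 nM, and the step of a 1.4-fold higher number from compound 1 to compound 2 (0.15 log units; within the scatter) is small, so the two numbers cannot be told apart.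

Compound 3, `CCCCNC1=CC(=O)C(C(C)(C)C)=CC1=O`, is built from the same atoms as compound 1, joined differently; the difference between the two cores is not broken down here. In this assay compound 3 gives 36000 nM. Set against compound 1 this is a clearly higher number, that is, weaker inhibition; set against compound 2 the gap is too small to count.

Compound 4, `CCCCCCCCNC1=CC(=O)C(C(C)(C)C)=CC1=O`, stands to compound 3 as compound 2 stands to compound 1: it differs by butyl in place of hydrogen on a saturated chain carbon, four bonds along the chain from an amine nitrogen, the same change at the same place. Within the data shown here, only one example of this change has been measured, and it barely moved the number. On the core of compound 3 the same small step is expected, so that a 1.4-fold higher number from compound 3 to compound 4 (0.14 log units; within the scatter) is estimated to resemble a 1.4-fold higher number from compound 1 to compound 2 (0.15 log units; within the scatter). Resting on 36000 nM for compound 3, compound 4 is expected to give about 50000 nM in this assay. Allowing for the usual spread, compound 4 is estimated to fall between 25000 nM and 100000 nM.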

Compound 4, half-maximal inhibitory concentration: 70000 nM
For compound 4 the middle estimate is 1.4-fold (0.15 log units) below the measured one, within the range that was stated.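

In this assay, the same lengthening of the amine chain on the core of compound 3 gives a 1.9-fold higher number from compound 3 to compound 4 (0.29 log units; within the scatter), so these two numbers cannot be told apart, just as the pair on the other core could not. Set side by side, the two steps also agree with each other, so within this small set the change carries over from one core to the other as a step too small to read: the same change on two cores in this assay, a 1.4-fold higher number (0.15 log units; within the scatter) from compound 1 to compound 2 and a 1.9-fold higher number (0.29 log units; within the scatter) from compound 3 to compound 4, 1.4-fold (0.13 log units) apart, within the scatter of two such steps This rests on only two pairs of compounds, and it shows neither that the chain length has no effect at all, as a modest real step could lie hidden in the scatter, nor that the same would hold on any core other than these two.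

The compounds shown leave open what a much shorter chain such as methyl, a longer chain than octyl, or a chain ending in an amine or a carboxylic acid would do on either core. They also leave open whether a ring in place of the straight chain would give a step large enough to read, and whether such a step would carry from one core to the other in the same way.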